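This account rests on a few compounds, and the source may have more. Where it says the series, first, only, none or still open, it means among the compounds named here.

Measured in a functional assay on MIA PaCa-2 cells (Homo sapiens) for cytotoxicity, read by fluorescence, with a stated time of 48 h; a lower number here means that less compound is needed, a higher number that more compound is needed for the effect:
- compound 1 `CC(C)=CCC/C(C)=C/CC/C(C)=C/CSC[C@H](NC(=O)CCCCCN1CCN(C)CC1)C(=O)NC1CC1`: 10400 nM
- compound 2 `CC(C)=CCC/C(C)=C/CC/C(C)=C/CSC[C@H](NC(=O)CCCCCN1CCCC1)C(=O)N1CCCCC1`: 12400 nM
- compound 3 `CC(C)=CCC/C(C)=C/CC/C(C)=C/CSC[C@H](NC(=O)CCCCCN1CCCC1)C(=O)NC1CCCCCCC1`: 1900 nM

Compound 3 holds the lowest number of the three, with compound 1 and compound 2 both higher beyond the scatter. Compound 4 `CC(C)=CCC/C(C)=C/CC/C(C)=C/CSC[C@H](NC(=O)CCCCCN1CCCC1)C(=O)NC1CC1` departs from it by cyclopropyl in place of cyclooctyl on an amide-type nitrogen. For the measured compounds named here, the one measured step touching this group is a 6.5-fold lower number from compound 2 to compound 3 (0.81 log units; beyond the scatter), a modest change that introduced the cyclooctylamino. Compound 1 carries the same cyclopropyl but differs elsewhere, and stands at 10400 nM. A rise of similar size, beyond the scatter, is therefore expected in this assay. The expected step is a 4.2-fold higher number from compound 3 to compound 4 (0.62 log units; beyond the scatter). Compound 4 is estimated at 8000 nM, with an expected range of 3500 nM to 18000 nM.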

Compound 4, half-maximal effective concentration: > 20000 nM
Compound 4 ended at the assay's limit (the forecaster's own chance of this, stated with the estimate: 10%); middle value at least 2.5-fold (0.39 log units) away from the limit.
By their numbers in this assay, from the lowest: compound 3; then compounds 1 and 2 (each within the scatter of the next). At a limit, above all of these: compound 4.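

With the pyrrolidin-1-yl chain held constant, cyclopropyl in place of cyclooctyl on the amide-type nitrogen gives an at least 10-fold higher number from compound 3 to compound 4 (1.02 log units; beyond the scatter), so the low number of compound 3 depends on the cyclooctyl among these compounds. The comparisons with the other two compounds stay unordered, as an at least 1.6-fold higher number from compound 2 to compound 4 (0.20 log units; that floor lies within the scatter) and an at least 1.9-fold higher number from compound 1 to compound 4 (0.28 log units; that floor lies within the scatter) are floors only. Compound 4 stands at a limit, not a number: the limit of > 20000 nM in this assay, at which 1 of the 4 values shown sits.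

Open, on these data alone, is whether a cyclohexyl or an open-chain octyl on this nitrogen keeps the low number. Also open, as far as these compounds go, is how cyclooctyl behaves with a 4-methylpiperazin-1-yl chain.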